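The source may hold more compounds than are shown below. What is called first, only, known or untested is meant among the compounds shown, and "the series" means these compounds.

Three compounds built on one shared core differ only in the group attached to a carbonyl carbon that sits on an amide-type nitrogen in a ring. In a physicochemical assay for solubility, read by HPLC (on this read-out lower numbers stand for lower solubility and higher numbers for higher solubility), compound 1 `O=C(c1ccccc1F)N1CCN(c2nc(=O)c3cc(C(F)(F)F)cc([N+](=O)[O-])c3s2)CC1` gives 3.1 ug/mL, compound 2 `Cc1ccc(C(=O)N2CCN(c3nc(=O)c4cc(C(F)(F)F)cc([N+](=O)[O-])c4s3)CC2)cc1` gives 6.7 ug/mL, and compound 3 `CC(C)CC(=O)N1CCN(c2nc(=O)c3cc(C(F)(F)F)cc([N+](=O)[O-])c3s2)CC1` gives 66.3 ug/mL, the highest of the three: the nearest is compound 2, with a 9.9-fold higher number from compound 2 to compound 3 (1.00 log units; beyond the scatter), and the furthest compound 1, with a 21-fold higher number from compound 1 to compound 3 (1.33 log units; beyond the scatter). Compound 4 `CC(C)(C)C1CCC(C(=O)N2CCN(c3nc(=O)c4cc(C(F)(F)F)cc([N+](=O)[O-])c4s3)CC2)CC1` takes a further step: 4-(tert-butyl)cyclohexyl in place of isobutyl on a carbonyl carbon. Neither measured step enlarges the chain at this position; both steps that raised the number replaced 2-fluorophenyl or 4-methylphenyl with isobutyl. Because a 9.9-fold higher number from compound 2 to compound 3 (1.00 log units; beyond the scatter) followed the loss of a ring, bringing a larger ring-bearing group in is expected to lower the number, with an 8.3-fold lower number from compound 3 to compound 4 (0.92 log units; beyond the scatter). Compound 4 is therefore estimated at 8 ug/mL, within 2 ug/mL to 30 ug/mL.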

Compound 4, solubility: < 0.1 ug/mL
Compound 4: a limit, no number; the forecaster's own chance of this, stated with the estimate: 10%; at least 80-fold (1.90 log units) between middle value and limit.
By their numbers in this assay, from the lowest: compound 1; then compound 2; then compound 3. At a limit, below all of these: compound 4.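

Compound 4 gives a limit of the assay, not a number: the limit of < 0.1 ug/mL in this assay, at which 1 of the 4 values shown sits.
Swapping an aromatic ring for a non-aromatic one does not raise the number at this position: 4-(tert-butyl)cyclohexyl gives an at least 67-fold lower number from compound 2 to compound 4 (1.82 log units; beyond the scatter) and an at least 31-fold lower number from compound 1 to compound 4 (1.49 log units; beyond the scatter). Against isobutyl it gives an at least 660-fold lower number from compound 3 to compound 4 (2.82 log units; beyond the scatter), so the absence of an aromatic ring alone does not secure a high number here.

From the compounds shown here alone, whether this drop follows the ring or the tert-butyl group on it stays open, and plain cyclohexyl would separate the two. Also open, going by these compounds, is how a group carrying an amine or a carboxylic acid would read here.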